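The source may report more compounds than this note shows. Statements on the series, on what has been measured and on what is new or still open speak of the compounds shown alone.

Measured so far in an ADME assay on Vero cells (Chlorocebus sabaeus) for inhibition, read by MTT assay, with a stated time of 72 h; on this read-out lower numbers stand for stronger inhibition and higher numbers for weaker inhibition:
Compound 1 `O=C(O)CCCCCCC(=O)Nc1ccc(C2=C(c3ccc(O)cc3)C3CC(S(=O)(=O)Oc4cccc5ccccc45)C2O3)cc1`: > 100000 nM, a limit
Compound 2 `Cc1ccccc1OS(=O)(=O)C1CC2OC1C(c1ccc(NC(=O)CCCCCCC(=O)O)cc1)=C2c1ccc(O)cc1`: > 100000 nM, a limit

Compound 2 has no numerical value and sits, with compound 1, at the limit of > 100000 nM in this assay, at which 2 of the 2 values shown sit. Compound 3 `Cc1ccc(OS(=O)(=O)C2CC3OC2C(c2ccc(NC(=O)CCCCCCC(=O)O)cc2)=C3c2ccc(O)cc2)cc1` carries 4-methylphenyl in place of 2-methylphenyl on an oxygen, whose other neighbour is the sulfonyl sulfur, and the two compounds have the same atoms, joined differently: 4-methylphenyl in place of 2-methylphenyl on an oxygen.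

Among the measured compounds shown here, the one measured change on this oxygen is a step that the two limits leave unreadable from compound 1 to compound 2, with 2-methylphenyl in place of naphthalen-1-yl. For the measured compounds named here, it gives no size to carry over, and it shows only that both groups leave the reading at the limit. With compound 2 at the limit of > 100000 nM, no step beyond the usual scatter is expected in this assay, and compound 3 will most likely be reported as a limit too.

The estimated change is a number no higher from compound 2 to compound 3 (the limit leaves the size open). The estimate for compound 3 is 100000 nM, with an expected range from 50000 nM to 200000 nM.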

Compound 3, half-maximal inhibitory concentration: > 100000 nM
Compound 3 gave a limit, no number; the forecaster's own chance of this, stated with the estimate: 85%; the middle value sits exactly at the limit.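

No step among compound 1, compound 2 and compound 3 can be read, and swapping naphthalen-1-yl, 2-methylphenyl and 4-methylphenyl on the oxygen gives no size, as all three compounds share one limit: the limit of > 100000 nM in this assay, at which 3 of the 3 values shown sit.

The compounds shown leave open how strongly any of them inhibits in this assay, and whether these groups differ at all.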